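The source may report more compounds than this note shows. Statements on the series, on what has been measured and on what is new or still open speak of the compounds shown alone.

Working notes on the series. Compound 3 `CC(C)(C)/N=C(\S)NCCCCn1nc(-c2ccccc2)ccc1=O` stands second highest of the three numbers in hand: in a functional assay on the whole organism with Rattus norvegicus as the target, at a dose of 100 mg/kg (a higher number here means more inhibition at the dose given (going by the name of the read-out), a lower number less inhibition), compound 3 gives 33.6%. Compound 2 `CC/N=C(/NC#N)NCCCCn1nc(-c2ccccc2)ccc1=O` is the nearest, with 58.8% in this assay, and compound 1 `CC/N=C(\S)NCCCCCCn1nc(-c2ccccc2)ccc1=O` the furthest, with -5.6%. Both steps from compound 1 are beyond the scatter, a number 64.4 percentage points higher from compound 1 to compound 2 (beyond the scatter) and a number 39.2 percentage points higher from compound 1 to compound 3 (beyond the scatter), and between the two closer compounds there is a number 25.2 percentage points lower from compound 2 to compound 3 (beyond the scatter).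

Compound 4 `CCC/N=C(/NC#N)NCCCCn1nc(-c2ccccc2)ccc1=O` is the next member to be measured. It differs from compound 3 as follows: a group of 8 heavy atoms (5 carbon, 3 nitrogen; no ring) in place of a group of 7 heavy atoms (5 carbon, 1 nitrogen, 1 sulfur; no ring), on an amine nitrogen. Within the data shown here, the one measured step that bears on this change is the one from compound 2 to compound 3, where the same kind of swap at the amine nitrogen, in the opposite direction, gave a number 25.2 percentage points lower from compound 2 to compound 3 (beyond the scatter), a modest step. Compound 4 also shares the entering group with compound 2, so the expectation is that the move back toward that group carries the number back up by a step of similar size, a number 21.4 percentage points higher from compound 3 to compound 4 (beyond the scatter) being the expected change. For compound 4 the estimate in this assay is therefore 55%, with a range from 35% to 75%.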

Compound 4, a percentage reported as inhibition, in the whole organism at one dose (the size of the read-out at that dose, not a potency): 26.3%
Compound 4: middle estimate off by 28.7 percentage points, on the high side; measured number below the stated range.
By their numbers in this assay, from the lowest: compound 1; then compounds 4 and 3 (each within the scatter of the next); then compound 2.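

In this assay, the nitrile-bearing group that enters at the amine nitrogen gives no recovery over the group that leaves, with a number 7.3 percentage points lower from compound 3 to compound 4 (within the scatter), so the return to the number of compound 2 does not follow from that group type alone. The smallest edit in the series carries the larger effect: methyl in place of hydrogen on a saturated chain carbon, two bonds along the chain from a double-bonded nitrogen, gives a number 32.5 percentage points lower from compound 2 to compound 4 (beyond the scatter), which shows that the end of this substituent matters and that the earlier a number 25.2 percentage points lower from compound 2 to compound 3 (beyond the scatter) cannot be read as a swap of sulfur for nitrile alone. No measurement in hand accounts for this sensitivity to one added methyl.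

Compounds 3 and 4 differ in both the sulfur-bearing part and the chain end, so the contribution of each remains unseparated. From the compounds shown here alone, whether the number keeps falling with a butyl or a longer chain at this end, or recovers with a cyclopropyl group, remains open, since one methyl step defines no trend.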